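A Bromophenyl Replaces the Hydroxynaphthyl Arm

A few compounds are considered here, and "the series" means these few. Any claim that something is new, unique, unknown or untested is made for them only; others in the source may bear on it.

Among the three compounds measured so far, compound 3 `CN(C)CCn1cnnc1-c1cc(Oc2ccc(NC(=O)N/N=C/c3c(O)ccc4ccccc34)cc2F)ccn1` stands lowest in a functional assay on A549 cells (Homo sapiens) for cytotoxicity, read by MTT assay, with a stated time of 72 h (a higher number here means a weaker inhibitor, a lower number a stronger inhibitor), where compound 3 gives 880 nM. Its two neighbours sit close together: compound 2 `CN(C)CCn1cnnc1-c1cc(Oc2ccc(NC(=O)N/N=C/c3ccccc3)cc2F)ccn1` gives 1860 nM and compound 1 `COc1ccc(OC)c(/C=N/NC(=O)Nc2ccc(Oc3ccnc(-c4nncn4CCN(C)C)c3)c(F)c2)c1` gives 1950 nM. The step between them, a 1.0-fold lower number from compound 1 to compound 2 (0.02 log units; within the scatter), shows that swapping phenyl for 2,5-dimethoxyphenyl changed nothing that can be trusted, whereas a 2.1-fold lower number from compound 2 to compound 3 (0.33 log units; beyond the scatter) and a 2.2-fold lower number from compound 1 to compound 3 (0.35 log units; beyond the scatter) show that the 2-hydroxynaphthalen-1-yl group brought a modest gain.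

Compound 4 `CN(C)CCn1cnnc1-c1cc(Oc2ccc(NC(=O)N/N=C/c3cccc(Br)c3)cc2F)ccn1` now takes the opposite direction from compound 3: 3-bromophenyl in place of 2-hydroxynaphthalen-1-yl on a carbon with a double bond to nitrogen. Two fused rings with one hydrogen-bond donor and one acceptor give way to a single ring carrying bromine and no donor or acceptor. Going by the values given here, the step that bears most directly on this is a 2.1-fold lower number from compound 2 to compound 3 (0.33 log units; beyond the scatter), since compound 2 also carries a single plain ring at this position; undoing that change is expected to undo most of its modest gain, and the bromine has no precedent here on which to lean. The expected step is therefore a 1.9-fold higher number from compound 3 to compound 4 (0.29 log units; within the scatter), putting compound 4 near compound 2 and compound 1. The estimate for compound 4 in this assay is 1700 nM, within a range from 850 nM to 3400 nM.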

Compound 4, half-maximal inhibitory concentration: 970 nM
Beside the measured number, compound 4's estimate is 1.8-fold (0.24 log units) above it; the measured number falls inside the stated range.
By their numbers in this assay, from the lowest: compounds 3, 4, 2 and 1 (each within the scatter of the next, the first and the last beyond it).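

In this assay, this position does not depend on the 2-hydroxynaphthalen-1-yl group alone: with one aromatic ring and no hydrogen-bond donor or acceptor, 3-bromophenyl cannot be told apart from it (a 1.1-fold higher number from compound 3 to compound 4 (0.04 log units; within the scatter)). Compound 4 also cannot be separated from the weaker pair, since bromo in place of hydrogen gives a 1.9-fold lower number from compound 2 to compound 4 (0.28 log units; within the scatter) and the swap for 2,5-dimethoxyphenyl gives a 2.0-fold lower number from compound 1 to compound 4 (0.30 log units; within the scatter), so it overlaps both compound 3 and compounds 2 and 1, even though compound 3 stands clear of those two, and the bromo effect stays unproven. No measurement shown here offers an explanation for this result.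

A plain naphthalen-1-yl group would help separate the contribution of the second ring from that of the hydroxyl, while a hydroxyl on a single phenyl ring would test the reverse case. On these data alone, it also remains open whether an amine or a carboxylic acid in place of the bromo on the phenyl ring would stay level with compound 4 or move clearly away from it.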